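Ring-closed hydroxyalkylamine on a purine guanidine scaffold

The compounds below may be only part of what the source reports. "The series", "measured", "known", "first", "only" and "open" are said of these compounds alone.

Compound 1, `CCCn1cnc2c(NC(=N)N)nc(N)nc21`: 36500 nM in a functional assay on MCF7 cells (Homo sapiens) for inhibition, read by fluorescence, with a stated time of 72 h; a lower number here means a stronger inhibitor, a higher number a weaker inhibitor
Compound 2, `Cn1cnc2c(NC(=N)N)ncnc21`: > 100000 nM in this assay, a limit rather than a number
Compound 3, `CC(C)n1cnc2c(NC(=N)N)nc(NCCCCCCO)nc21`: 5200 nM in this assay

Compound 3 gives the lowest of the two numbers in this assay; compound 1 sits a good deal higher, beyond the scatter. Compound 2 reaches only (the limit of > 100000 nM in this assay, at which 1 of the 3 values shown sits), so its number is not known.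

Compound 4, `CC(C)n1cnc2c(NC(=N)N)nc(N3CCC[C@@H]3CO)nc21`, has not been measured. It differs from compound 3 in one place: 2-(hydroxymethyl)pyrrolidin-1-yl in place of (6-hydroxyhexyl)amino on an aromatic carbon. The hydroxyl group stays, but the chain is shortened and closed into a ring on the same aromatic carbon of a six-membered aromatic ring with 2 nitrogen, part of a fused or bridged system of two rings.

Going by the values given here, with no measured step of this kind to lean on, compound 4 is expected to land close to compound 3, with a step of a 1.2-fold higher number from compound 3 to compound 4 (0.06 log units; within the scatter) that is expected to stay within the scatter. The estimate for compound 4 is 6000 nM, with a range from 1500 nM to 25000 nM.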

Compound 4, half-maximal inhibitory concentration: 20400 nM
Estimate against measurement, compound 4: 3.4-fold (0.53 log units) below, and the stated range covers the measured number.
By their numbers in this assay, from the lowest: compound 3; then compounds 4 and 1 (each within the scatter of the next). At a limit, above all of these: compound 2.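

Closing the (6-hydroxyhexyl)amino chain into 2-(hydroxymethyl)pyrrolidin-1-yl on this aromatic carbon, between two ring nitrogen atoms, does change the result in this assay, giving a 3.9-fold higher number from compound 3 to compound 4 (0.59 log units; beyond the scatter). The position therefore responds to the form of the group it carries, and keeping a hydroxyl group does not by itself keep the number of the open chain. No measurement shown here bears on why the number moves.

The compounds shown leave open whether the hydroxyl group matters at all at this position, and whether a longer chain, or a chain ending in an amine or a carboxylic acid, would give a lower number. They also leave open how the opposite stereoisomer of the 2-(hydroxymethyl)pyrrolidin-1-yl group would compare.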